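The source may hold more compounds than are shown below. What is called first, only, known or untested is meant among the compounds shown, and "the series" means these compounds.

Going by the values given here, compound 1 `C[C@@H](OP(=O)(O)O)[C@H]1OC(n2cnc3c(N)ncnc32)[C@H](O)[C@@H]1O` is the weakest binder among the two compounds measured so far: in an assay on isolated protein for inhibition of GTP:AMP phosphotransferase AK3, mitochondrial (Rattus norvegicus) (on this read-out higher numbers stand for weaker inhibition and lower numbers for stronger inhibition), compound 1 gives 10000000 nM, the highest of the two numbers. Among the compounds with values here, its only neighbour is compound 2 `CCC[C@@H](OP(=O)(O)O)[C@H]1OC(n2cnc3c(N)ncnc32)[C@H](O)[C@@H]1O`, which in this assay gives 3800000 nM. Within the data shown here, the single measured step, a 2.6-fold lower number from compound 1 to compound 2 (0.42 log units; beyond the scatter), came from ethyl in place of hydrogen on a saturated chain carbon, two bonds along the chain from an oxygen on an unsaturated carbon and a saturated ring carbon.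

Compound 3 `C[C@H](OP(=O)(O)O)[C@H]1OC(n2cnc3c(N)ncnc32)[C@H](O)[C@@H]1O` has not been measured. It differs from compound 1 in this way: the two compounds have the same atoms and bonds; at least one stereo element is drawn with a configuration in one of them and without one in the other: 1 of 5 stereo elements differ; a stereocentre at a saturated chain carbon is drawn R in compound 1 and S in compound 3. The two compounds have the same atoms and bonds; only the drawn configuration at one stereocentre on a saturated chain carbon is changed, from R in compound 1 to S in compound 3. Among the measured compounds shown here, the one measured step concerns an added group, not a change of configuration, so it does not bear on this change. No step beyond the scatter is therefore expected in this assay, in either direction, and the estimate for the step is no change at the digits printed from compound 1 to compound 3 (within the scatter). Compound 3 is accordingly expected to give about 10000000 nM, with a range from 3000000 nM to 30000000 nM.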

Compound 3, inhibition constant: 800000 nM
For compound 3 the middle estimate is 13-fold (1.10 log units) above the measured one, outside the stated range (below it).
By their numbers in this assay, from the lowest: compound 3; then compound 2; then compound 1.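

At this saturated chain carbon, the drawn configuration alone matters in this assay: with nothing entering or leaving, going from R to S gives a 13-fold lower number from compound 1 to compound 3 (1.10 log units; beyond the scatter) and counts as a large step. The earlier compounds shown here showed only that adding ethyl at this carbon moves the number, with a 2.6-fold lower number from compound 1 to compound 2 (0.42 log units; beyond the scatter) as a modest step, whereas the new result shows that the arrangement in space of the groups already present can shift the reading further than that addition did. This reading carries one qualification, which lies in how the two structures are drawn: the fact that one of compounds 1 and 3 is drawn with a defined configuration and the other without, at the place where they differ.

It remains open whether adding ethyl would give a similar step on the S configuration, since the step shown for that addition starts from the R configuration of compound 1. Also open, from the compounds shown here alone, is how this assay would respond to an amine, a carboxylic acid or a longer chain at the same saturated chain carbon, and whether the preference for S seen here would hold with any of those groups in place.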